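A thioether analogue with a larger aromatic ring

The source may report more compounds than this note shows. Statements on the series, on what has been measured and on what is new or still open speak of the compounds shown alone.

Compound 1 `CS(=O)(=O)c1ccc(-c2nc3ccccn3c2Sc2ccccc2)cc1` is measured in a functional assay on HepG2 cells (Homo sapiens) for inhibition, read by MTT assay, with a stated time of 48 h (on this read-out higher numbers stand for weaker inhibition and lower numbers for stronger inhibition), where compound 1 gives 13200 nM. Among the measured compounds shown here, this is the lower of the two numbers available: its companion compound 2 `Cc1ccc(-c2nc3ccccn3c2Sc2ccccc2)cc1` gives 67900 nM in this assay, and the one recorded step, a 5.1-fold higher number from compound 1 to compound 2 (0.71 log units; beyond the scatter), concerns a methyl in place of methylsulfonyl on an aromatic carbon. Compound 3 `CS(=O)(=O)c1ccc(-c2nc3ccccn3c2Sc2cccc3ccccc23)cc1` differs from compound 1 elsewhere: naphthalen-1-yl in place of phenyl on a sulfur. For the measured compounds named here, no measured step touches the group on this sulfur, so the recorded step offers no guide to the size or direction of the change, and nothing suggests a shift beyond the usual scatter. On that basis the step from compound 1 to compound 3 is expected to be a 1.3-fold lower number from compound 1 to compound 3 (0.12 log units; within the scatter). In this assay compound 3 is therefore estimated at 10000 nM, with a likely range from 3000 nM to 40000 nM.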

Compound 3, half-maximal inhibitory concentration: 13600 nM
Compound 3: middle estimate off by 1.4-fold (0.13 log units), on the low side, and the stated range covers the measured number.
By their numbers in this assay, from the lowest: compounds 1 and 3 (each within the scatter of the next); then compound 2.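

In this assay, naphthalen-1-yl in place of phenyl on a sulfur gives a 1.0-fold higher number from compound 1 to compound 3 (0.01 log units; within the scatter) and so leaves the two compounds inseparable on this read-out, even though the group grows from 6 to 10 heavy atoms and gains a second six-membered aromatic ring. The earlier step, at the aromatic carbon, gave a 5.1-fold higher number from compound 1 to compound 2 (0.71 log units; beyond the scatter) and was beyond the scatter, whereas this first look at the group on the sulfur shows that this particular enlargement can be made with no change beyond the scatter. No separate evidence is available to explain this result.

Still open, as far as these compounds go, is whether a group on this sulfur that carries an amine or a carboxylic acid would behave in the same way. Also open, from the compounds shown here alone, is whether naphthalen-1-yl would have as little effect with methyl on the aromatic carbon, as in compound 2.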